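A few compounds are considered here, and "the series" means these few. Any claim that something is new, unique, unknown or untested is made for them only; others in the source may bear on it.

Compound 1 `COc1ccc(-c2cc(O)c3c(C)cc(C)nc3n2)cc1` — 28800 nM
Compound 2 `COc1cccc(-c2cc(O)c3c(C)cc(C)nc3n2)c1` — < 10 nM
Compound 3 `COc1cccc(-c2cc(O)c3c(C)ccnc3n2)c1` — < 10 nM

Going by the values given here, in a functional assay on MDA-MB-435 cells (Homo sapiens) (on this read-out lower numbers stand for stronger inhibition of growth and higher numbers for weaker inhibition of growth), compound 1 gives 28800 nM, the only value here that is a plain number. For compound 2 the read-out is a limit of the assay, < 10 nM. For compound 3 the read-out is also a limit, < 10 nM. Compound 1 and compound 2 are built from the same atoms joined differently, and the difference between the two cores is not broken down here. From compound 2 to compound 3 the change is hydrogen in place of methyl on an aromatic carbon and the step is a step that the two limits leave unreadable from compound 2 to compound 3.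

Compound 4 `COc1ccc(-c2cc(O)c3ccc(C)nc3n2)cc1` is not yet measured in this assay. It differs from compound 1 by the same kind of change, (hydrogen in place of methyl on an aromatic carbon), though the surroundings differ: in compound 4 the carbon is ortho to a fused ring and opposite the ring nitrogen, whereas in compound 3 it is next to the ring nitrogen and para to a fused ring. Because the limit of < 10 nM in this assay, at which 2 of the 3 values shown sit, leaves the measured step unreadable, its size gives no guide. The expectation rests on compound 1 at 28800 nM. For compound 4 the expected step is a 1.0-fold higher number from compound 1 to compound 4 (0.02 log units; within the scatter). The estimate for compound 4 is 30000 nM, expected between 8000 nM and 100000 nM.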

Compound 4, concentration for 50% growth inhibition: 42700 nM
Compound 4: middle estimate off by 1.4-fold (0.15 log units), on the low side; measured number inside the range.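

In this assay, putting hydrogen in place of the methyl on the core of compound 1 gives a 1.5-fold higher number from compound 1 to compound 4 (0.17 log units; within the scatter), so on this core the change makes no difference that stands out from the usual scatter of repeated measurements. The same kind of change on the other core gives no comparison, and its step cannot be read, because both compounds there sit at a limit of the assay: the limit of < 10 nM in this assay, at which 2 of the 4 values shown sit. This leaves one readable step on one core, which does not show that the change carries from one core to another, and the methyl lost from compound 1 sits opposite the ring nitrogen, a place different from that of the methyl lost from compound 2.

Still open, from the compounds shown here alone, is whether another group on the carbon opposite the ring nitrogen, such as an ethyl chain or an amine, would move the number on the core of compound 1. Also open, going by these compounds, is the size of any step on the core of compound 2, where plain numbers would be needed on both sides.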